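Loss of chloro from compound 2: expected effect on growth

The source may hold more compounds than are shown below. What is called first, only, known or untested is meant among the compounds shown, and "the series" means these compounds.

Two members of this series have numbers in an ADME assay on PANC-1 cells (Homo sapiens) for inhibition, read by MTT assay, with a stated time of 90 h; a higher number here means a weaker inhibitor of growth, a lower number a stronger inhibitor of growth. Compound 1, `O=C(CC(=O)c1ccccc1O)c1cc2ccccc2s1`, gives 7.77 ug/mL in this assay. Compound 2, `Cc1cc(O)c(C(=O)CC(=O)c2cc3ccccc3s2)cc1Cl`, gives 20.4 ug/mL in this assay, the highest of the two numbers; compound 1 is the nearest and sits at a lower number, and the gap between them lies beyond the scatter. Among the measured compounds shown here, no step between these two is computed, as they differ in more than one place, so only the two values themselves can be set side by side.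

Compound 3, `Cc1ccc(C(=O)CC(=O)c2cc3ccccc3s2)c(O)c1`, has not been measured. It derives from compound 2 by the change (hydrogen in place of chloro on an aromatic carbon), in words hydrogen in place of chloro on an aromatic carbon. Compound 3 thus keeps the methyl group of compound 2 but not its chloro, which brings it nearer in structure to compound 1. Compound 1 at 7.77 ug/mL sits below compound 2 at 20.4 ug/mL, and compound 3 is expected to fall between them. The expected step is a 1.7-fold lower number from compound 2 to compound 3 (0.23 log units; within the scatter), a moderate move toward a stronger inhibitor of growth, probably no larger than the gap between compound 2 and compound 1. Compound 3 is therefore estimated at 12 ug/mL, within a range from 6 ug/mL to 25 ug/mL.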

Compound 3, concentration for 50% growth inhibition: 9.24 ug/mL
Compound 3: middle estimate off by 1.3-fold (0.11 log units), on the high side; the measured number falls inside the stated range.
By their numbers in this assay, from the lowest: compounds 1 and 3 (each within the scatter of the next); then compound 2.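

In this assay, among the compounds shown here, hydrogen in place of the chloro that stands ortho to a methyl group and para to a hydroxy group gives a 2.2-fold lower number from compound 2 to compound 3 (0.34 log units; beyond the scatter), a modest step and the first single-place change at this position that can be read beyond the scatter. The methyl group alone gives a 1.2-fold higher number from compound 1 to compound 3 (0.08 log units; within the scatter), so on this pair it makes no readable difference, and the gap that compound 1 and compound 2 showed without a step now splits into a methyl change within the scatter and a chloro change beyond it. Nothing on hand gives a reason for the chloro step, whose size is all that can be stated.

Open, as far as these compounds go, is whether the chloro step holds on the core of compound 1 without the methyl group, since both chloro and methyl sit together only in compound 2. Equally open, from the compounds shown here alone, is how fluoro, bromo, methoxy or an amine in place of chloro at this position would read, and whether any such group would take the number clear of the scatter around compound 1 and compound 3.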